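Tetrazole swap on a phenoxy ketone: a step toward compound 4

A few compounds are considered here, and "the series" means these few. Any claim that something is new, unique, unknown or untested is made for them only; others in the source may bear on it.

The series is built on an aryl ether ketone carrying a tetrazole on the chain carbon bound to the carbonyl, tested in an assay on microsomes from brain for inhibition of Fatty-acid amide hydrolase 1 (Rattus norvegicus), read by fluorescence and HPLC, with a stated time of 60 min; on this read-out higher numbers stand for weaker inhibition and lower numbers for stronger inhibition. Compound 1 `CCCCCCCCc1ccc(OCC(=O)Cn2nnc(C)n2)cc1` gives 27 nM, compound 2 `CCCCCCCCc1ccc(OCC(=O)Cn2nnc(SC)n2)cc1` gives 31 nM, and compound 3 `CCCCCCCCc1ccc(OCC(=O)Cn2nnc(C(=O)OC)n2)cc1` gives 88 nM. Compound 3 has the highest number of the three; its nearest neighbour is compound 2, with a 2.8-fold higher number from compound 2 to compound 3 (0.45 log units; beyond the scatter), and the furthest is compound 1, with a 3.3-fold higher number from compound 1 to compound 3 (0.51 log units; beyond the scatter).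

Compound 4 `CCCCCCCCc1ccc(OCC(=O)Cn2nnnc2C)cc1` has not yet been measured in this assay. Its structure differs from compound 3 in one place: 5-methyl-1H-tetrazol-1-yl in place of 5-(methoxycarbonyl)-2H-tetrazol-2-yl on a saturated chain carbon bound to a carbonyl carbon. The bearing steps are those that exchanged the substituent on the tetrazole: the change a 3.3-fold higher number from compound 1 to compound 3 (0.51 log units; beyond the scatter) and the change a 2.8-fold higher number from compound 2 to compound 3 (0.45 log units; beyond the scatter) both made the number higher by a modest margin, while a 1.1-fold higher number from compound 1 to compound 2 (0.06 log units; within the scatter) stayed within the scatter. For the measured compounds named here, compound 4 reverses that exchange by restoring a methyl group, but it also moves the attachment from the 2H to the 1H tetrazole nitrogen, for which no measured pair exists.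

Compound 4 is therefore expected to show a modest step downward, a 2.5-fold lower number from compound 3 to compound 4 (0.40 log units; beyond the scatter), in this assay. Compound 4 is estimated at 35 nM, within a range from 12 nM to 110 nM.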

Compound 4, half-maximal inhibitory concentration: 41 nM
Beside the measured number, compound 4's estimate is 1.2-fold (0.07 log units) below it; low and high end bracket the measured number.
By their numbers in this assay, from the lowest: compounds 1, 2 and 4 (each within the scatter of the next); then compound 3.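

In this assay, the exchange of 5-methyl-2H-tetrazol-2-yl for 5-methyl-1H-tetrazol-1-yl on a saturated chain carbon bound to a carbonyl carbon gave a 1.5-fold higher number from compound 1 to compound 4 (0.18 log units; within the scatter) and so supplied the pair that had been missing: for the methyl-bearing tetrazole, the change of attachment shows no effect that can be told from the scatter. For the compounds shown here, the comparison with the methylsulfanyl compound, a 1.3-fold higher number from compound 2 to compound 4 (0.12 log units; within the scatter), likewise stays within the scatter, whereas the exchange for the methoxycarbonyl group gave a 2.1-fold lower number from compound 3 to compound 4 (0.33 log units; beyond the scatter), leaving 5-(methoxycarbonyl)-2H-tetrazol-2-yl as the only one of the four groups that stands apart, with the other three not to be ordered among themselves. The data at hand offer nothing that explains this difference.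

From the compounds shown here alone, the methoxycarbonyl and methylsulfanyl groups appear here only on the 2H-attached tetrazole, and whether the 1H attachment would read the same with either of them remains open. Also open, going by these compounds, is how a carboxylic acid or an amine in place of the methyl group on the tetrazole would read.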